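A few compounds are considered here, and "the series" means these few. Any claim that something is new, unique, unknown or untested is made for them only; others in the source may bear on it.

Measured compounds in a functional assay on M21 cells (Homo sapiens) for antiproliferative activity, read by sulforhodamine B assay, with a stated time of 48 h; on this read-out higher numbers stand for weaker inhibition and lower numbers for stronger inhibition:
- compound 1, `CC(C)c1ccccc1OS(=O)(=O)c1cccc(NC(=O)C(C)(C)C)c1`: 13000 nM
- compound 2, `CC(=O)Nc1ccc(S(=O)(=O)Oc2ccccc2C(C)C)cc1`: 21000 nM
- compound 3, `CC(=O)Nc1ccc(S(=O)(=O)Oc2ccccc2I)cc1`: 27000 nM

Compound 2 stands second highest of the three numbers in this assay. Its nearest neighbour is compound 3, and the gap a 1.3-fold higher number from compound 2 to compound 3 (0.11 log units; within the scatter) is within the scatter. Its furthest neighbour is compound 1, whose number is lower, yet the two values of compound 1 and compound 2 also lie within the scatter of each other, so no order can be read among the three.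

The unmeasured compound 4, `CCCC(=O)Nc1ccc(S(=O)(=O)Oc2ccccc2C(C)C)cc1`, differs from compound 2 only in the amide chain: ethyl in place of hydrogen on a saturated chain carbon bound to a carbonyl carbon. Within the data shown here, none of the measured steps touches this part of the molecule; the one step that exists, a 1.3-fold higher number from compound 2 to compound 3 (0.11 log units; within the scatter), concerns the aromatic substituent of the sulfonate ester and was within the scatter. Compound 1 carries a different acyl group on a differently substituted aryl, so its value bears on the change only loosely, and what it shows is a number within the scatter of that of compound 2.

With no step beyond the scatter anywhere in the set, the expectation for compound 4 in this assay is no change beyond the scatter, that is an expected step of a 1.2-fold lower number from compound 2 to compound 4 (0.07 log units; within the scatter). Compound 4 is therefore estimated at 18000 nM, with a range from 7000 nM to 45000 nM.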

Compound 4, half-maximal inhibitory concentration: 6100 nM
Beside the measured number, compound 4's estimate is 3.0-fold (0.47 log units) above it; the measured number lies below the stated range.
By their numbers in this assay, from the lowest: compound 4; then compounds 1, 2 and 3 (each within the scatter of the next, the first and the last beyond it).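

In this assay, among these compounds, the amide chain is the first place where a single change moves the number beyond the scatter: ethyl in place of hydrogen on a saturated chain carbon bound to a carbonyl carbon, which turns methyl into propyl, gives a 3.4-fold lower number from compound 2 to compound 4 (0.54 log units; beyond the scatter). Among the compounds shown here, the only earlier single-place step, a 1.3-fold higher number from compound 2 to compound 3 (0.11 log units; within the scatter), lay at the aromatic substituent of the sulfonate ester and stayed within the scatter, so this position is, on one pair only, the one of the two places that responds in this assay, and the response is modest. Nothing available bears on the origin of this step.

Open, on these data alone, is whether a longer chain such as pentyl continues the fall in the number or reverses it, and whether a branched chain or a terminal amine or carboxylic acid on the propyl chain keeps it. Also open, as far as these compounds go, is whether the same change from methyl to propyl carries over to the core of compound 3, which bears iodo in place of isopropyl, so one pair cannot yet be called a trend.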